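Swapping methoxy for morpholin-4-yl on a carbonyl carbon

The compounds below may be only part of what the source reports. "The series", "measured", "known", "first", "only" and "open" are said of these compounds alone.

Measured in a functional assay on HCT-116 cells (Homo sapiens) for inhibition, read by MTT assay, with a stated time of 72 h; a lower number here means a stronger inhibitor of growth, a higher number a weaker inhibitor of growth:
- compound 1 `CN1CCN(C(=O)/C=C/c2ccncc2-c2ccc3ccccc3c2)CC1`: > 30000 nM (a limit of the assay, not a number)
- compound 2 `CNC(=O)/C=C/c1ccncc1-c1ccc2ccccc2c1`: 6550 nM
- compound 3 `COC(=O)/C=C/c1ccncc1-c1ccc2ccccc2c1`: 350 nM

Compound 3 has the lowest number of the three, and its nearest neighbour is far off: a 19-fold lower number from compound 2 to compound 3 (1.27 log units; beyond the scatter). The next candidate is compound 4 `O=C(/C=C/c1ccncc1-c1ccc2ccccc2c1)N1CCOCC1`, and the change is morpholin-4-yl in place of methoxy on a carbonyl carbon.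

All three measured steps concern this same place. Both compounds without methoxy there have much higher numbers, and neither goes against this trend. The second large step is an at least 85-fold lower number from compound 1 to compound 3 (1.93 log units; beyond the scatter), and it matters most. Compound 1 carries 4-methylpiperazin-1-yl, the measured group nearest to morpholin-4-yl. The remaining step is an at least 4.5-fold lower number from compound 1 to compound 2 (0.66 log units; beyond the scatter).

A large step towards weaker growth inhibition is therefore expected in this assay. The estimated step is a 29-fold higher number from compound 3 to compound 4 (1.46 log units; beyond the scatter). For compound 4 the expected value is 10000 nM, with an estimated range from 2500 nM to 30000 nM.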

Compound 4, concentration for 50% growth inhibition: 6040 nM
Compound 4: middle estimate off by 1.7-fold (0.22 log units), on the high side, within the range that was stated.
By their numbers in this assay, from the lowest: compound 3; then compounds 4 and 2 (each within the scatter of the next). At a limit, above all of these: compound 1.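

In this assay, the new compound gives a 17-fold higher number from compound 3 to compound 4 (1.24 log units; beyond the scatter), while the comparison with methylamino gives a 1.1-fold lower number from compound 2 to compound 4 (0.04 log units; within the scatter), so methoxy now stands apart from morpholin-4-yl as well, and the ring of morpholin-4-yl brings no readable difference from methylamino at this carbonyl carbon. Morpholin-4-yl and 4-methylpiperazin-1-yl are also separated, with an at least 4.9-fold lower number from compound 1 to compound 4 (0.69 log units; beyond the scatter), and that step is only a minimum. The entry for compound 1 is a limit of the assay, not a number: the limit of > 30000 nM in this assay, at which 1 of the 4 values shown sits.

The compounds shown leave open whether the low number belongs to methoxy alone or to oxygen-linked groups in general, which an ethoxy group or a carboxylic acid at this place would test. Also open, from the compounds shown here alone, is whether a dimethylamino group, which lacks the amide hydrogen of compound 2, would fall with compound 2 and compound 4.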